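Three isothiocyanate analogues and a shortened reversed-amide analogue

The source may report more compounds than this note shows. Statements on the series, on what has been measured and on what is new or still open speak of the compounds shown alone.

Three compounds sharing one core were tested in a functional assay on A549 cells (Homo sapiens) for inhibition, read by CCK-8 assay, with a stated time of 72 h, tested at 10 uM; on this read-out higher numbers stand for a stronger effect at the one concentration tested and lower numbers for a weaker effect. Compound 1 `CN(C)C(=O)c1cc2cnc(Nc3ccc(S(=O)(=O)NCCCCCN=C=S)cc3)nc2n1C1CCCC1` gives 102%. Compound 2 `CN(C)C(=O)c1cc2cnc(Nc3ccc(C(=O)NCCCCN=C=S)cc3)nc2n1C1CCCC1` gives 102% in this assay. Compound 3 `CN(C)C(=O)c1cc2cnc(Nc3ccc(C(=O)NCCCCCCN=C=S)cc3)nc2n1C1CCCC1` gives 100% in this assay. All three numbers sit within the scatter of one another: no change at the digits printed from compound 1 to compound 2 (within the scatter), a number 2 percentage points lower from compound 1 to compound 3 (within the scatter), and a number 2 percentage points lower from compound 2 to compound 3 (within the scatter). Compound 3 therefore stands indistinguishable from compound 1 and compound 2 on these numbers.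

Compound 4 `CN(C)C(=O)c1cc2cnc(Nc3ccc(NC(=O)CCCN=C=S)cc3)nc2n1C1CCCC1` is not yet measured. Compared with compound 3, the change is a group of 9 heavy atoms (5 carbon, 2 nitrogen, 1 oxygen, 1 sulfur; no ring) in place of a group of 12 heavy atoms (8 carbon, 2 nitrogen, 1 oxygen, 1 sulfur; no ring), on an aromatic carbon. The measured steps bearing on it are those that alter the substituent on the same aromatic carbon, namely a number 2 percentage points lower from compound 1 to compound 3 (within the scatter) and a number 2 percentage points lower from compound 2 to compound 3 (within the scatter), both within the scatter, and the swap of a larger side chain in no change at the digits printed from compound 1 to compound 2 (within the scatter), also within the scatter. Every change so far at this position has left the read-out near full inhibition, so compound 4 is expected to show no step beyond the scatter in this assay, with the estimated step being a number 1 percentage points lower from compound 3 to compound 4 (within the scatter). The estimate for compound 4 in this assay is 99%, with a range from 87% to 104%.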

Compound 4, a percentage reported as inhibition, at one concentration (the size of the read-out at that concentration, not a potency): 102%
Compound 4: the middle estimate sits 3 percentage points below what was measured; the measured number falls inside the stated range.
By their numbers in this assay, from the lowest: compounds 3, 1, 2 and 4 (each within the scatter of the next).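

In this assay, reversing the amide link on the aromatic carbon and shortening the chain, so that a smaller group takes the place of a larger one, gives a number 2 percentage points higher from compound 3 to compound 4 (within the scatter). The comparisons with the other two side chains agree, with no change at the digits printed from compound 2 to compound 4 (within the scatter) and no change at the digits printed from compound 1 to compound 4 (within the scatter), so this aromatic carbon now carries a sulfonamide, an amide and a reversed amide link with no step beyond the scatter, and the smallest side chain shown stands level with the larger ones. No supporting evidence bears on why the read-out holds across these changes.

All four compounds carry the isothiocyanate, so the compounds shown leave open how a chain ending in an amine, or a plain alkyl chain without that end group, would read in this assay. All four also sit near full inhibition at a single concentration, which leaves open whether the reversed amide would give a stronger or weaker effect than the amide and sulfonamide links at any other concentration.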